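The source may hold more compounds than are shown below. What is called first, only, known or untested is meant among the compounds shown, and "the series" means these compounds.

Two closely related nucleoside analogues have been measured for their ability to slow the growth of a human leukaemia cell line. Compound 1 `OC[C@H]1O[C@@H](n2cnc3c(NCc4ccccc4Cl)ncnc32)[C@H](O)[C@@H]1O` gives 1600 nM in a functional assay on HL-60 cells (Homo sapiens) for antiproliferative activity, with a stated time of 72 h; a higher number here means a weaker inhibitor, a lower number a stronger inhibitor. Going by the values given here, compound 2 `OC[C@H]1O[C@@H](n2cnc3c(NCc4ccc(Cl)cc4)ncnc32)[C@H](O)[C@@H]1O` gives 1700 nM in this assay; it has the higher of the two numbers, but its only neighbour is compound 1, and the gap between them is a 1.1-fold higher number from compound 1 to compound 2 (0.03 log units; within the scatter), so the two compounds cannot be told apart on this evidence.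

Compound 3 `COc1ccccc1CNc1ncnc2c1ncn2[C@@H]1O[C@H](CO)[C@@H](O)[C@H]1O` is not yet measured. It differs from compound 2 in one place: 2-methoxyphenyl in place of 4-chlorophenyl on a saturated chain carbon bound to a nitrogen on an aromatic ring.

Among the compounds with values here, the only measured step available, a 1.1-fold higher number from compound 1 to compound 2 (0.03 log units; within the scatter), moved the chlorine from one position of the ring to another and left the number essentially unchanged. Within the data shown here, no measured pair shows a methoxy group taking the place of chlorine, so there is no direct guide for that part of the change. Among the measured compounds shown here, with a single, flat step as the only precedent, the expectation for compound 3 is a step of about a 1.1-fold higher number from compound 2 to compound 3 (0.02 log units; within the scatter), that is, no movement beyond the scatter, with a wide range to reflect the missing precedent. Compound 3 is therefore estimated at 1800 nM in this assay, expected to fall between 500 nM and 7000 nM.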

Compound 3, half-maximal inhibitory concentration: 2300 nM
The estimate for compound 3 lay 1.3-fold (0.11 log units) below the measured number; low and high end bracket the measured number.
By their numbers in this assay, from the lowest: compounds 1, 2 and 3 (each within the scatter of the next).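

The result shows that this position tolerates a change of group as well as a shift of the chlorine. In this assay, the swap of 4-chlorophenyl for 2-methoxyphenyl, which brings in an oxygen and a hydrogen-bond acceptor, gives a 1.4-fold higher number from compound 2 to compound 3 (0.13 log units; within the scatter), and methoxy in place of chloro on an aromatic carbon gives a 1.4-fold higher number from compound 1 to compound 3 (0.16 log units; within the scatter), so both steps stay inside the normal noise of the measurement and all three compounds remain indistinguishable. No independent measurement is available to explain this flat behaviour.

The compounds shown leave open whether any group at this place can move the number beyond the scatter, since all three carry a singly substituted phenyl ring and an amine or a carboxylic acid on that ring, or a longer chain in place of the benzyl link, has no reading here. On these data alone, the shared core is also the same in all three, so the effect of a change there remains unknown.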